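The source may report more compounds than this note shows. Statements on the series, on what has been measured and on what is new or still open speak of the compounds shown alone.

Measured compounds:
- Compound 1 `CNCc1cc(-c2cccnc2F)n(S(=O)(=O)c2cccnc2)c1` — in a functional assay on the whole organism (strain Jcl:Sprague-Dawley) for inhibition, with Rattus norvegicus as the target, with stated times of 3 min and 3 h, at a dose of 1 mg/kg by the intravenous route (a lower number here means less inhibition, a higher number more inhibition at the dose given (going by the name of the read-out)), compound 1 gives 96%
- Compound 2 `CNCc1cc(-c2cccnc2F)n(S(=O)(=O)c2ccccn2)c1` — in this assay compound 2 gives 81%
- Compound 3 `CNCc1cn(S(=O)(=O)c2cccs2)c(-c2cccnc2F)c1F` — in this assay compound 3 gives 98%

Compound 3 carries the highest of the three numbers, yet its gap to compound 1 lies within the usual scatter of repeated measurements, so the two cannot be told apart; only compound 2 sits clearly lower, beyond the scatter. Within the data shown here, all three share a core in which a sulfonyl sulfur bears an aromatic group, and the one measured step that touches that position, a number 15 percentage points lower from compound 1 to compound 2 (beyond the scatter), shows that swapping one six-membered aromatic group for another on that sulfur can move the read-out by a modest but real amount.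

Compound 4 `CNCc1cn(S(=O)(=O)c2cccc(OC)n2)c(-c2cccnc2F)c1F` differs from compound 3 only at that same sulfur: 6-methoxypyridin-2-yl in place of thiophen-2-yl on a sulfonyl sulfur. Among the measured compounds shown here, no measured pair covers this exact exchange, so the step from compound 1 to compound 2 is the closest guide. It points to a modest loss when a pyridin-2-yl sits on the sulfonyl sulfur, and the entering group here is of that kind. A step in the same direction, of similar or somewhat larger size, is therefore expected, a number 14 percentage points lower from compound 3 to compound 4 (beyond the scatter). Compound 4 is thus estimated to give 84%, with a range from 65% to 98%.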

Compound 4, a percentage reported as inhibition, in the whole organism at one dose (the size of the read-out at that dose, not a potency): 98%
Beside the measured number, compound 4's estimate is 14 percentage points below it; the measured number falls inside the stated range.
By their numbers in this assay, from the lowest: compound 2; then compounds 1, 3 and 4 (each within the scatter of the next).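

The exchange of thiophen-2-yl for 6-methoxypyridin-2-yl on the sulfonyl sulfur gives no change at the digits printed from compound 3 to compound 4 (within the scatter) in this assay, so on the core of compound 3 this position accepts a larger group with a six-membered aromatic ring and keeps the read-out high. The drop of a number 15 percentage points lower from compound 1 to compound 2 (beyond the scatter) therefore does not act as a general rule for groups of the pyridin-2-yl kind on this sulfur, since compound 4 goes against it, although that drop was measured on a different core and the two steps cannot be read as one effect. Nothing measured here gives a reason why the larger group is accepted.

The compounds shown leave open whether the methoxy group contributes anything, since plain pyridin-2-yl on the core of compound 3 is not among them, and whether an amine or a carboxylic acid in its place would hold the read-out. Compound 3 and compound 4 also both stand close to the top of a percentage scale, which leaves this single-dose read-out little room to separate groups that perform well at this position.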